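A few compounds are considered here, and "the series" means these few. Any claim that something is new, unique, unknown or untested is made for them only; others in the source may bear on it.

Compound 1 `NC1=NC2(CCSCC2)N(OCCCOc2cccc(Cl)c2)C(N)=N1`: 260 nM
Compound 2 `NC1=NC2(CCOCC2)N(OCCCOc2ccccc2Br)C(N)=N1`: 610 nM

In a functional assay on HL-60 cells (Homo sapiens) for antiproliferative activity, read by MTT assay, with a stated time of 72 h (on this read-out lower numbers stand for stronger inhibition and higher numbers for weaker inhibition), compound 1 has the lower of the two numbers at 260 nM, while compound 2 gives 610 nM, and this gap lies beyond the usual scatter. Within the data shown here, no two measured compounds differ in just one place, so the data give no direct guide to the size of a single change.

Compound 3 `NC1=NC2(CCSCC2)N(OCCCOc2ccccc2Cl)C(N)=N1` has not yet been measured. It is built from compound 1 by one change: 2-chlorophenyl in place of 3-chlorophenyl on an oxygen on a saturated carbon, which puts 2-chlorophenyl in place of 3-chlorophenyl on an oxygen on a saturated carbon. The atoms stay the same and are only joined differently. The expected 1.2-fold higher number from compound 1 to compound 3 (0.09 log units; within the scatter) in this assay is small, with no shift beyond the scatter and perhaps a slight drift towards weaker inhibition. For compound 3 the estimated value is 320 nM, with an expected range from 130 nM to 800 nM.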

Compound 3, half-maximal inhibitory concentration: 390 nM
For compound 3 the middle estimate is 1.2-fold (0.09 log units) below the measured one; measured number inside the range.
By their numbers in this assay, from the lowest: compounds 1, 3 and 2 (each within the scatter of the next, the first and the last beyond it).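

Among these compounds, the step between compound 1 and compound 3 is the first comparison here of two compounds that differ in one place. In this assay having 2-chlorophenyl in place of 3-chlorophenyl on an oxygen on a saturated carbon comes with a 1.5-fold higher number from compound 1 to compound 3 (0.18 log units; within the scatter) and so shows that, in this pair, rejoining the same atoms leaves no difference that can be told from the usual scatter. No measurement on hand offers an explanation for this result.

The compounds shown leave open whether a different group at this place, such as an unsubstituted phenyl or a pyridine ring, would give a step beyond the scatter. They also leave open whether the same swap of chlorophenyl groups would give a similar step with a longer chain.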